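A few compounds are considered here, and "the series" means these few. Any claim that something is new, unique, unknown or untested is made for them only; others in the source may bear on it.

Of the compounds shown here, three sharing one core have been measured in an assay on CHO cells for agonist activity at 5-hydroxytryptamine receptor 1D (Homo sapiens), read by GTPgammaS binding; on this read-out lower numbers stand for an effect already at smaller amounts and higher numbers for an effect only at larger amounts of compound. Compound 1 `O=S(=O)(NCC1CCN(CCCc2c[nH]c3ccc(-n4cnnc4)cc23)CC1)c1ccccc1` gives 12 nM there, which is the highest of the three numbers. Compound 2 `OCCC(NC1CCN(CCCc2c[nH]c3ccc(-n4cnnc4)cc23)CC1)c1ccccc1` gives 5.1 nM, and compound 3 `NC(=O)OC[C@H](NC1CCN(CCCc2c[nH]c3ccc(-n4cnnc4)cc23)CC1)c1ccccc1` gives 9.3 nM. The step of a 2.4-fold lower number from compound 1 to compound 2 (0.37 log units; beyond the scatter) lies beyond the scatter, while the step of a 1.8-fold higher number from compound 2 to compound 3 (0.26 log units; within the scatter) does not, and compound 1 and compound 3 sit within the scatter of each other.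

Compound 4 `C[C@H](NC1CCN(CCCc2c[nH]c3ccc(-n4cnnc4)cc23)CC1)c1ccccc1` has not yet been measured. Relative to compound 1 it differs in one place: (1-phenylethyl)amino in place of ((phenylsulfonyl)amino)methyl on a saturated ring carbon. The step from compound 1 to compound 2 is the one that bears on this change, since it too replaces the ((phenylsulfonyl)amino)methyl group on the saturated ring carbon with an amino-linked group carrying a phenyl ring; that step gave a modestly lower number. Compound 4 carries the smaller (1-phenylethyl)amino group, so a similar or slightly smaller shift is expected. Compound 4 is therefore estimated at 8 nM in this assay, with a range from 3 nM to 25 nM, meaning an expected step of a 1.5-fold lower number from compound 1 to compound 4 (0.18 log units; within the scatter).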

Compound 4, half-maximal effective concentration: 12 nM
The estimate for compound 4 lay 1.5-fold (0.18 log units) below the measured number; the range from low to high includes it.
By their numbers in this assay, from the lowest: compounds 2, 3, 1 and 4 (each within the scatter of the next, the first and the last beyond it).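

In this assay, the exchange on the saturated ring carbon gives no change at the digits printed from compound 1 to compound 4 (within the scatter), so the lower number seen with compound 2 does not come with every amino-linked group carrying a phenyl ring. On the amine nitrogen, 1-phenylethyl in place of 3-hydroxy-1-phenylpropyl gives a 2.4-fold higher number from compound 2 to compound 4 (0.37 log units; beyond the scatter), which means that the side chain beyond the phenyl-bearing carbon can shift the number, though only modestly. Hydrogen in place of carbamoyloxy gives a 1.3-fold higher number from compound 3 to compound 4 (0.11 log units; within the scatter), so this group on the saturated chain carbon shows no effect beyond the scatter.

No measured evidence here explains these steps. From the compounds shown here alone, compound 2 differs from compound 4 in both chain length and its hydroxyl group, so it remains open which of these matters, and whether an unsubstituted propyl chain or a terminal amine would behave like the hydroxyl-bearing chain.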